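Piperazine Amide Series: Aryl Substituent Effect on Macrophage Cytotoxicity

The compounds below may be only part of what the source reports. "The series", "measured", "known", "first", "only" and "open" are said of these compounds alone.

For the measured compounds named here, compound 2 `CC(=O)N1CCN(C(=O)c2nc3cc(C(F)(F)F)ccc3s2)CC1` stands with the highest of the two numbers so far; in an ADME assay on RAW264.7 cells (Mus musculus) for cytotoxicity, read by MTT assay, with a stated time of 72 h, tested at 50 ug/mL (a lower number here means less inhibition, a higher number more inhibition at the concentration tested (going by the name of the read-out)), compound 2 gives 20.2%, whereas compound 1 `CN1CCN(C(=O)c2nc3cc(C(F)(F)F)ccc3s2)CC1` gives 12.6%. Going by the values given here, the only step recorded, a number 7.6 percentage points higher from compound 1 to compound 2 (within the scatter), is the sole guide to compound 3 `CC(=O)c1ccc(N2CCN(C(=O)c3nc4cc(C(F)(F)F)ccc4s3)CC2)cc1`, which carries the change (4-acetylphenyl in place of acetyl on an amine nitrogen in a ring). That step was small, and nothing measured here tells how a larger aromatic group behaves, so a step of a number 4.8 percentage points higher from compound 2 to compound 3 (within the scatter) is expected, staying within the scatter but with wide uncertainty. Compound 3 is therefore estimated at 25%, within 5% to 50%.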

Compound 3, a percentage reported as inhibition, at one concentration (the size of the read-out at that concentration, not a potency): 30.6%
Estimate against measurement, compound 3: 5.6 percentage points below; measured number inside the range.
By their numbers in this assay, from the lowest: compounds 1 and 2 (each within the scatter of the next); then compound 3.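

In this assay the amine nitrogen in the ring gives its first steps beyond the scatter with 4-acetylphenyl, a number 10.4 percentage points higher from compound 2 to compound 3 (beyond the scatter) and a number 18 percentage points higher from compound 1 to compound 3 (beyond the scatter), both modest. The position therefore responds to this larger aromatic group, whereas methyl and acetyl stayed within the scatter of each other. Nothing available accounts for the rise. Going by these compounds, whether the six-membered aromatic ring or its acetyl carries the step stays open. So does what a plain phenyl, a benzyl or a 4-carboxyphenyl group would give on that nitrogen.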